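Butyl to tert-butyl in a small series

The source may hold more compounds than are shown below. What is called first, only, known or untested is meant among the compounds shown, and "the series" means these compounds.

Of the compounds shown here, three share one core and have numbers so far. In a functional assay on RPMI-8226 cells (Homo sapiens) for inhibition (a lower number here means a stronger inhibitor, a higher number a weaker inhibitor), compound 1 (`CCOC(=O)CNC(=O)N1CC1C#N`) gives 30000 nM and compound 2 (`CCCCNC(=O)N1CC1C#N`) gives 17000 nM, two values within the scatter of each other. Compound 3 (`N#CC1CN1C(=O)Nc1ccc(F)cc1`) gives 5900 nM, and its gap to compound 2 lies beyond the scatter. Compound 2 therefore stands with compound 1, apart from compound 3.

Compound 4 (`CC(C)(C)NC(=O)N1CC1C#N`) differs from compound 2 as follows: tert-butyl in place of butyl on an amide-type nitrogen. Among the compounds with values here, no measured pair isolates a change of this kind, so the expectation rests on the spread alone. Compound 2 at 17000 nM is the natural anchor, and compound 1 at 30000 nM lies within the scatter of it. In this assay, the estimated step of a 1.2-fold higher number from compound 2 to compound 4 (0.07 log units; within the scatter) is expected to stay within the scatter, with no firm direction. For compound 4 the estimated value is 20000 nM, with an expected range of 8000 nM to 50000 nM.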

Compound 4, half-maximal inhibitory concentration: 216000 nM
Compound 4: the middle estimate sits 11-fold (1.03 log units) below what was measured; the measured number lies above the stated range.
By their numbers in this assay, from the lowest: compound 3; then compounds 2 and 1 (each within the scatter of the next); then compound 4.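

In this assay, within the data shown here, the place on the amide-type nitrogen whose other neighbour is the carbonyl carbon proves sensitive to how its four carbons are joined, with a 13-fold higher number from compound 2 to compound 4 (1.10 log units; beyond the scatter) as the first step that isolates one change. The step is large even though butyl and tert-butyl match in heavy atoms, and neither group brings a ring, hydrogen-bond donor, hydrogen-bond acceptor or net charge, so rearranging the same carbons is enough to shift the number here. Nothing available accounts for the size of this step.

The compounds shown leave open whether this loss belongs to tert-butyl alone or extends to smaller or differently branched groups such as isopropyl or isobutyl. Also open, going by these compounds, is how a longer chain such as hexyl at the same place would compare with compound 2.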